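Ethoxypyridine amines against metabotropic glutamate receptor 5: aryl variation

The compounds below may be only part of what the source reports. "The series", "measured", "known", "first", "only" and "open" are said of these compounds alone.

Measured so far in an assay on Ltk cells with metabotropic glutamate receptor 5 (Homo sapiens) as the target, read by fluorescence and calcium flux; on this read-out lower numbers stand for stronger inhibition and higher numbers for weaker inhibition:
compound 1, `CCOc1cc(-c2ccccc2C#N)cnc1Nc1cccc(C)n1`, 37 nM
compound 2, `CCOc1cc(-c2cccnc2)cnc1Nc1cccc(C)n1`, 12 nM
compound 3, `CCOc1cc(Oc2cccnc2)cnc1Nc1cccc(C)n1`, 18 nM

Compound 3 sits second highest of the three numbers. Its nearest neighbour is compound 2, at a 1.5-fold higher number from compound 2 to compound 3 (0.18 log units; within the scatter), a step within the scatter; its furthest is compound 1, at a 2.1-fold lower number from compound 1 to compound 3 (0.31 log units; beyond the scatter), beyond the scatter. Compound 1 also stands apart from compound 2 at a 3.1-fold lower number from compound 1 to compound 2 (0.49 log units; beyond the scatter).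

The next compound, compound 4, `CCOc1cc(-c2cnccc2C)cnc1Nc1cccc(C)n1`, differs from compound 3 in one place: 4-methylpyridin-3-yl in place of (pyridin-3-yl)oxy on an aromatic carbon.

Among the measured compounds shown here, two measured steps bear on this. The step of a 1.5-fold higher number from compound 2 to compound 3 (0.18 log units; within the scatter) shows that moving between a directly attached pyridin-3-yl and a (pyridin-3-yl)oxy made no difference beyond the scatter, so returning to a direct attachment is expected to stay close to compound 2 and compound 3. For the measured compounds named here, the added methyl on the pyridine ring has no precedent among the measured compounds, and its effect cannot be read from them. On balance no step beyond the scatter is expected; the working estimate for the change is a 1.3-fold lower number from compound 3 to compound 4 (0.11 log units; within the scatter).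

Compound 4 is therefore estimated at 14 nM in this assay, with a range from 5 nM to 45 nM.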

Compound 4, half-maximal inhibitory concentration: 45 nM
Compound 4: the middle estimate sits 3.2-fold (0.51 log units) below what was measured; measured number inside the range.
By their numbers in this assay, from the lowest: compounds 2 and 3 (each within the scatter of the next); then compounds 1 and 4 (each within the scatter of the next).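

In this assay the single added methyl gives a 3.8-fold higher number from compound 2 to compound 4 (0.57 log units; beyond the scatter) and so carries a cost beyond the scatter at this position, para to the (6-methylpyridin-2-yl)amino group, where the change from pyridin-3-yl to (pyridin-3-yl)oxy had stayed within it. The comparison with the oxygen-linked ring points the same way, with a 2.5-fold higher number from compound 3 to compound 4 (0.40 log units; beyond the scatter) on going to 4-methylpyridin-3-yl, while a 1.2-fold higher number from compound 1 to compound 4 (0.09 log units; within the scatter) leaves that group within the scatter of 2-cyanophenyl. Among these four compounds, the two whose attached ring carries a further substituent, compound 1 and compound 4, therefore give the higher numbers, and no compound shown goes against this, though no measurement shown explains the effect of the methyl.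

Still open, going by these compounds, is whether this cost belongs to methyl itself or would also appear with a fluoro, methoxy or amino group on the same pyridine carbon. It is also unresolved whether a methyl at another carbon of the pyridine ring, or the same methyl on the (pyridin-3-yl)oxy group, would give a comparable step.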